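Para substitution on the phenylpiperazine ring: methyl to isopropenyl

The source may report more compounds than this note shows. Statements on the series, on what has been measured and on what is new or still open speak of the compounds shown alone.

Compound 1 `Cc1ccc(N2CCN(C(=O)c3oc(C)nc3-c3ccccc3)CC2)cc1`: > 1000 nM
Compound 2 `Cc1nc(-c2ccccc2)c(C(=O)N2CCN(c3cccc(C#N)c3)CC2)o1`: 39.6 nM
Compound 3 `Cc1nc(-c2ccccc2)c(C(=O)N2CCN(c3ccccc3)CC2)o1`: 39.1 nM

In a functional assay on HL-60 cells (Homo sapiens) for inhibition, read by MTT assay, with a stated time of 72 h (on this read-out higher numbers stand for weaker inhibition and lower numbers for stronger inhibition), compound 3 gives 39.1 nM, the lowest of the two numbers shown, with compound 2 within the scatter of it. Compound 1 reaches only a limit of the assay, > 1000 nM, shown as the limit of > 1000 nM in this assay, at which 1 of the 3 values shown sits. Compound 4 `C=C(C)c1ccc(N2CCN(C(=O)c3oc(C)nc3-c3ccccc3)CC2)cc1` differs from compound 3 by 1-methylethenyl in place of hydrogen on an aromatic carbon, on the same ring where compound 1 carries its methyl. The step that bears on this is an at least 25-fold lower number from compound 1 to compound 3 (1.40 log units; beyond the scatter), a large one in this assay; compound 4 adds a group at that place again, and so a large step back toward weaker inhibition is expected. Compound 4 is estimated at 2000 nM (range 200 nM to 20000 nM), an expected step of a 51-fold higher number from compound 3 to compound 4 (1.71 log units; beyond the scatter).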

Compound 4, half-maximal inhibitory concentration: "not active" (no number reported)
No number was reported for compound 4; the estimate stays without a comparison.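

Among the compounds shown here, compound 4 is reported only as "not active", without a number, so no step from compound 3 or compound 1 to compound 4 can be read. The compounds shown leave open how compound 4 compares with compound 1, whose value is only a limit: the limit of > 1000 nM in this assay, at which 1 of the 4 values shown sits.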